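The source may report more compounds than this note shows. Statements on the series, on what has been measured and on what is new or still open speak of the compounds shown alone.

Measured in an ADME assay on HEK293 cells (Homo sapiens) for cytotoxicity, read by resazurin assay, with a stated time of 16 h; on this read-out higher numbers stand for an effect only at larger amounts of compound and lower numbers for an effect already at smaller amounts:
- Compound 1 `C=CCOc1ccc(/C=C/C(=O)CC(=O)/C=C/c2ccc(O)c(OC)c2)cc1OC`: 270000 nM
- Compound 2 `COc1cc(/C=C/C(=O)CC(=O)/C=C/c2ccc(OCC=C(C)C)c(OC)c2)ccc1O`: > 500000 nM

Compound 2 gives only a limit of the assay, > 500000 nM, and not an exact number. Compound 3 `COc1cc(/C=C/C(=O)CC(=O)/C=C/c2ccc(OCC=C(C)C)c(OC)c2)ccc1OCC=C(C)C` keeps compound 2 but turns its free hydroxy into (3-methylbut-2-en-1-yl)oxy: 3-methylbut-2-en-1-yl in place of hydrogen on an oxygen on an aromatic ring. For the measured compounds named here, the one measured step that bears on this is an at least 1.8-fold higher number from compound 1 to compound 2 (0.26 log units; that floor lies within the scatter), which also altered a chain on an oxygen on an aromatic ring. It sets no firm size, so only a small upward change, or none beyond the scatter, is expected in this assay. The expected step is a step that the limit leaves unreadable from compound 2 to compound 3. For compound 3 the estimate is 600000 nM, with an expected range of 250000 nM to 1500000 nM.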

Compound 3, half-maximal effective concentration: > 1000000 nM
Compound 3: no number, only a limit; the forecaster's own chance of this, stated with the estimate: 75%; at least 1.6-fold (0.22 log units) between middle value and limit.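

In this assay compound 2 gives only a limit, > 500000 nM. Compound 3 also gives only a limit, > 1000000 nM. For the compounds shown here, no step from compound 2 to compound 3 can therefore be read. The compounds shown leave open whether 3-methylbut-2-en-1-yl in place of hydrogen changes the value at all.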